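A few compounds are considered here, and "the series" means these few. Any claim that something is new, unique, unknown or untested is made for them only; others in the source may bear on it.

Measured so far in an ADME assay on the whole organism (plasma, Mus musculus) for pharmacokinetics, read by LC-MS, at a dose of 30 mg/kg by the oral route; on this read-out lower numbers stand for lower exposure and higher numbers for higher exposure at the dose given:

Compound 1, `NCc1cc(Oc2cccc(C(=O)NCc3cc4ccccc4s3)c2)nc(C(F)(F)F)c1`, stands at "not determined" (no result reported) in this assay.
Compound 2, `NCc1cc(Oc2cccc(C(=O)NCCn3cnnn3)c2)nc(C(F)(F)F)c1`, gives 1990 nM in this assay.
Compound 3, `NCc1cc(Oc2cccc(C(=O)NC[C@@H](O)CO)c2)nc(C(F)(F)F)c1`, gives 2770 nM in this assay.

Among the compounds with values here, compound 3 thus holds the higher of the two numbers available, with compound 2 as its only measured neighbour; the step of a 1.4-fold higher number from compound 2 to compound 3 (0.14 log units; within the scatter) stays within the scatter, so the two cannot be told apart on these data. Compound 4, `NCc1cc(Oc2cccc(C(=O)N3CC[C@@H](O)C3)c2)nc(C(F)(F)F)c1`, differs from compound 3 in one place: 3-hydroxypyrrolidin-1-yl in place of (2,3-dihydroxypropyl)amino on a carbonyl carbon. Within the data shown here, the only measured step that bears on this is the one from compound 2 to compound 3, which also changed the group on the amide side of the shared core and produced no change beyond the scatter. Among the measured compounds shown here, no measured step closes the amide nitrogen into a ring as the change to compound 4 does, so that part of the change has no precedent here. For the measured compounds named here, with the one relevant step flat, no step beyond the scatter is expected in this assay, in either direction. For compound 4 the expected value is 2500 nM, within a range of 1000 nM to 6000 nM, an expected step of a 1.1-fold lower number from compound 3 to compound 4 (0.04 log units; within the scatter).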

Compound 4, maximal plasma concentration: 5130 nM
Estimate against measurement, compound 4: 2.1-fold (0.31 log units) below; the measured number falls inside the stated range.
By their numbers in this assay, from the lowest: compounds 2, 3 and 4 (each within the scatter of the next, the first and the last beyond it).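

In this assay, closing the amide nitrogen into a ring, with 3-hydroxypyrrolidin-1-yl in place of (2,3-dihydroxypropyl)amino on a carbonyl carbon, gives a 1.9-fold higher number from compound 3 to compound 4 (0.27 log units; within the scatter) and so cannot be told apart from the open chain, even though the group goes from 3 hydrogen-bond donors to 1. The same ring in place of the tetrazole-bearing chain gives a 2.6-fold higher number from compound 2 to compound 4 (0.41 log units; beyond the scatter) and is the only step among these three compounds that clears the scatter, which shows that this position can shift exposure at the dose given, if only modestly. Nothing measured here gives a reason for either step. 

Still open, from the compounds shown here alone, is whether the ring hydroxyl or its defined stereocentre matters at all. Going by these compounds, how an unsubstituted pyrrolidine, a morpholine or a piperazine would behave on the same carbonyl carbon also remains unknown.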